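This account rests on a few compounds, and the source may have more. Where it says the series, first, only, none or still open, it means among the compounds named here.

Compound 1 `C=CCNC(=O)/C(C)=C(/C)c1ccc(OC)cc1` gives 400 mg/kg in a toxicity assay on the whole organism (strain Icem-CET (SPF Caw)) for cytotoxicity, with Mus musculus as the target; a lower number here means that less compound is needed, a higher number that more compound is needed for the effect.
Compound 2 `COc1ccc(/C(C)=C(/C)C(=O)NC2CC2)cc1` gives 300 mg/kg.
Compound 3 `COc1ccc(/C(C)=C(\C)C(=O)NC2CC2)cc1` gives 250 mg/kg.

Among these three numbers compound 2 stands second highest; its nearest neighbour is compound 3, reached by a 1.2-fold lower number from compound 2 to compound 3 (0.08 log units; within the scatter), and the furthest is compound 1, from which a 1.3-fold lower number from compound 1 to compound 2 (0.12 log units; within the scatter). Both steps stay within the scatter, so the three compounds cannot be told apart here.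

Compound 4 `C/C(C(=O)NC1CC1)=C(\C)c1ccccc1` is the next candidate. Relative to compound 2 the change is hydrogen in place of methoxy on an aromatic carbon. Neither measured step touches the aromatic ring: one swaps the group on the amide nitrogen, the other only the drawn configuration of the double bond, and both were small. With no closer guide, no step beyond the scatter is expected in this assay. Compound 4 is therefore estimated at 300 mg/kg, within 150 mg/kg to 600 mg/kg. The expected step is no change at the digits printed from compound 2 to compound 4 (within the scatter).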

Compound 4, dose for half-maximal effect: 300 mg/kg
Compound 4: middle estimate and measured number agree at the digits printed; the measured number falls inside the stated range.
By their numbers in this assay, from the lowest: compounds 3, 2, 4 and 1 (each within the scatter of the next).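

In this assay, hydrogen in place of methoxy on the aromatic carbon para to a large group gives no change at the digits printed from compound 2 to compound 4 (within the scatter). For the compounds shown here, the earlier steps left the aromatic ring untouched, so this is the first sign that the methoxy at this position can go without a readable shift in the dose. Nothing available here speaks to why this is so.

As far as these compounds go, whether an amine, a carboxylic acid or a longer chain at this position would shift the number beyond the scatter stays open. So does whether the same swap would behave alike on compound 3, with its other drawn double-bond configuration.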